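Chloro for hydrogen on a second purine-type core

A few compounds are considered here, and "the series" means these few. Any claim that something is new, unique, unknown or untested is made for them only; others in the source may bear on it.

Measured compounds in a functional assay on ACHN cells (Homo sapiens) for cytotoxicity, read by sulforhodamine B assay, with a stated time of 48 h; on this read-out higher numbers stand for weaker inhibition of growth and lower numbers for stronger inhibition of growth:
compound 1 `ClCc1ccccc1Cn1cnc2c(Cl)nc(Cl)nc21`: 1620 nM
compound 2 `ClCc1ccccc1Cn1cnc2c(Cl)ncnc21`: 6160 nM
compound 3 `ClCc1ccccc1Cn1cnc2ncnc(Cl)c21`: 4260 nM

The series carries one unchanged side group and varies the fused core and its chlorine substitution. Compound 2 and compound 1 differ in one place only, (chloro in place of hydrogen on an aromatic carbon); the step is a 3.8-fold lower number from compound 2 to compound 1 (0.58 log units; beyond the scatter). Compound 3 has the same atoms as compound 2 joined differently; the difference between the two cores is not broken down here. In this assay compound 3 gives 4260 nM, which sits close to compound 2 and well apart from compound 1.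

The unmeasured compound 4 `ClCc1ccccc1Cn1cnc2nc(Cl)nc(Cl)c21` stands to compound 3 as compound 1 stands to compound 2: chloro in place of hydrogen on an aromatic carbon. The place line of this change reads the same as for the pair compound 2 to compound 1, so it is the same change carried onto the core of compound 3. Among the measured compounds shown here, only one measured instance of the change exists, and the two cores are not the same, so the transfer is uncertain.

For the measured compounds named here, the step from compound 3 to compound 4 is expected to be a 3.3-fold lower number from compound 3 to compound 4 (0.52 log units; beyond the scatter), resting on the single measured step of a 3.8-fold lower number from compound 2 to compound 1 (0.58 log units; beyond the scatter) applied to compound 3 at 4260 nM. Compound 4 is therefore estimated at 1300 nM, with a range from 500 nM to 3500 nM.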

Compound 4, concentration for total growth inhibition: 1250 nM
The estimate for compound 4 lay 1.0-fold (0.02 log units) above the measured number; the range from low to high includes it.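

In this assay, chloro in place of hydrogen on an aromatic carbon, between two ring nitrogen atoms, gives a 3.4-fold lower number from compound 3 to compound 4 (0.53 log units; beyond the scatter), so the change that lowered the number on the core of compound 2 also lowers it on the core of compound 3. The size of the step carries over between these two cores, with no difference that can be told apart from the scatter: the same change on two cores in this assay, a 3.8-fold lower number (0.58 log units; beyond the scatter) from compound 2 to compound 1 and a 3.4-fold lower number (0.53 log units; beyond the scatter) from compound 3 to compound 4, 1.1-fold (0.05 log units) apart, within the scatter of two such steps

Among the compounds shown here, this shows that the step transfers between two related cores in one cell assay, but it rests on only two pairs, says nothing of further cores or other cell lines, and does not explain why the number falls.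

The compounds shown place only hydrogen or chloro at this ring carbon, so it remains open whether an amine, a methoxy group or a fluoro group there would give a step of similar size. All four compounds also carry the same side group, leaving open how the number would respond if its chloromethyl group were replaced by a hydroxymethyl group or a longer chain.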